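Swapping the sulfamoylphenyl of compound 1 for a pyridinyl

This account rests on a few compounds, and the source may have more. Where it says the series, first, only, none or still open, it means among the compounds named here.

Compound 1 `NS(=O)(=O)c1ccc(-c2nc(C(c3ccc(F)cc3)c3ccc(F)cc3)sc2CC(=O)O)cc1` was tested in an in vitro functional assay on HEK285-7 cells for antagonist activity at prostaglandin D2 receptor 2 (Homo sapiens), read by BRET and beta-arrestin recruitment (a higher number here means a larger maximal response, a lower number a smaller maximal response), and gives 80%. Two related compounds were measured alongside it. Compound 3 `O=C(O)Cc1sc(C(c2ccccc2)c2ccc(F)c(F)c2)nc1-c1ccc(F)cc1` gives 80% in this assay, and compound 2 `O=C(O)Cc1sc(COc2ccc(Cl)cc2)nc1-c1ccc(Cl)cc1` gives 50% there. On these numbers compound 1 stands level with compound 3 at the digits shown, the two together forming the top of the three values, while compound 2 lies a good way lower, a gap that is beyond the usual scatter of such measurements.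

The next compound, compound 4 `O=C(O)Cc1sc(C(c2ccc(F)cc2)c2ccc(F)cc2)nc1-c1ccncc1`, differs from compound 1 in one place: pyridin-4-yl in place of 4-sulfamoylphenyl on an aromatic carbon. For the measured compounds named here, no measured pair in this set isolates this exact change, so its effect in this assay has to be judged from the three values alone. Since compound 1 and compound 3 sit at the same level despite differing in several places, the author expects the change to compound 4 to shift the maximal response only modestly, if at all, with any movement more likely downward than upward. The step from compound 1 to compound 4 is expected to be a number 5 percentage points lower from compound 1 to compound 4 (within the scatter). Compound 4 is therefore estimated at 75%, within a range from 55% to 95%.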

Compound 4, largest response reached (reported as efficacy), in percent of the reference or control that the assay uses: 80%
Compound 4: the middle estimate sits 5 percentage points below what was measured, and the stated range covers the measured number.
By their numbers in this assay, from the lowest: compound 2; then compounds 1, 3 and 4 (each within the scatter of the next).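

In this assay the position next to the ring nitrogen now has its first single-place comparison, and replacing 4-sulfamoylphenyl with pyridin-4-yl gives no change at the digits printed from compound 1 to compound 4 (within the scatter). Within this pair, the maximal response therefore does not depend on keeping the 4-sulfamoylphenyl group: the substituent can go from 10 heavy atoms to 6, lose its hydrogen-bond donor and exchange its carbon-only ring for one with a hetero atom, and the reading stays within the scatter. Nothing available here bears on why the reading holds across this change.

The compounds shown leave open how far this holds at the same position, for example whether a 4-carboxyphenyl, a 4-aminophenyl or a pyridin-3-yl group would leave the response equally unmoved. They also leave open whether the same exchange would behave in this way with a different large group on the ring in place of the bis(4-fluorophenyl)methyl group that compound 1 and compound 4 share, such as a simple benzyl or a longer chain.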